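The compounds below may be only part of what the source reports. "The series", "measured", "known", "first", "only" and "open" are said of these compounds alone.

Working notes on the series. The shared core is carried by compound 1 `c1ccc2c(c1)CN[C@@H](CN(CCCCNCC1CCNCC1)[C@H]1CCCc3cccnc31)C2`, compound 2 `c1ccc2c(c1)CN[C@@H](CN(CCCCNC1CCSCC1)[C@H]1CCCc3cccnc31)C2` and compound 3 `NCc1ccccc1CN(C[C@H]1Cc2ccccc2CN1)[C@H]1CCCc2cccnc21`. In a functional assay on cells for antagonist activity at C-X-C chemokine receptor type 4 (Homo sapiens), read by fluorescence and calcium flux, with stated times of 25 min and 90 s (on this read-out lower numbers stand for stronger inhibition and higher numbers for weaker inhibition), compound 1 gives 36.5 nM, compound 2 gives 54.7 nM and compound 3 gives 50.8 nM. On these numbers compound 3 stands second highest of the three, with compound 2 nearest and compound 1 furthest, all three within the scatter of one another; the step of a 1.5-fold higher number from compound 1 to compound 2 (0.18 log units; within the scatter) is likewise within the scatter.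

Compound 4 `CC(C)(N)CCCN(C[C@H]1Cc2ccccc2CN1)[C@H]1CCCc2cccnc21` differs from compound 3 by 3-amino-3-methylbutyl in place of 2-(aminomethyl)phenyl on a saturated chain carbon bound to an amine nitrogen. Among the compounds with values here, the steps that bear on this change are the two exchanges of the group on the same saturated chain carbon bound to an amine nitrogen that lead into compound 3, and both were small: a 1.4-fold higher number from compound 1 to compound 3 (0.14 log units; within the scatter) and a 1.1-fold lower number from compound 2 to compound 3 (0.03 log units; within the scatter). No step beyond the scatter is therefore expected for compound 4, an expected step of a 1.1-fold higher number from compound 3 to compound 4 (0.03 log units; within the scatter). The estimate for compound 4 in this assay is 55 nM, with a range from 25 nM to 120 nM.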

Compound 4, half-maximal inhibitory concentration: 24.6 nM
Estimate against measurement, compound 4: 2.2-fold (0.35 log units) above; measured number outside the range, below it.
By their numbers in this assay, from the lowest: compounds 4, 1, 3 and 2 (each within the scatter of the next, the first and the last beyond it).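

In this assay, the position on a saturated chain carbon bound to an amine nitrogen proves sensitive to its group: 3-amino-3-methylbutyl in place of 2-(aminomethyl)phenyl gives a 2.1-fold lower number from compound 3 to compound 4 (0.31 log units; beyond the scatter), so a group with no ring can replace the aromatic one without loss. The exchange of ((thian-4-yl)amino)methyl for 1-amino-1-methylethyl, three bonds along the chain from an amine nitrogen, also goes beyond the scatter, with a 2.2-fold lower number from compound 2 to compound 4 (0.35 log units; beyond the scatter), whereas the same exchange from the piperidine-bearing group stays within it, with a 1.5-fold lower number from compound 1 to compound 4 (0.17 log units; within the scatter). Nothing available accounts for these steps.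

The compounds shown leave open whether the step in compound 4 follows from the open chain alone or needs the branched carbon carrying the amine. An unbranched 4-aminobutyl group, or a carboxylic acid in place of the amine, would separate these readings.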